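Piperidinyl for phenyl on an aminophenyl biphenyl series

The source may report more compounds than this note shows. Statements on the series, on what has been measured and on what is new or still open speak of the compounds shown alone.

Compound 1 `N#Cc1ccc(NCc2cncn2Cc2ccc(-c3ccccc3)cc2N)cc1-c1ccccc1` in a toxicity assay on NIH3T3 cells (Mus musculus) for cytotoxicity, read by resazurin assay; on this read-out lower numbers stand for an effect already at smaller amounts and higher numbers for an effect only at larger amounts of compound: compound 1 gives > 1000 nM, a limit.
Compound 2 `c1ccc(-c2ccc(Cn3cncc3CNc3ccc(-c4ccccc4)c(-c4ccccc4)c3)cc2)cc1`: compound 2 gives > 10000 nM, a limit.
Compound 3 `COC(=O)c1ccc(NCc2cncn2Cc2cccc(C)c2)cc1-c1ccccc1`: compound 3 gives > 10000 nM, a limit.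

None of the three measured compounds returns a number in this assay; each result is a limit of the assay. Compound 2 sits at the higher of the two limits, shared with compound 3 (the limit of > 10000 nM in this assay, at which 2 of the 3 values shown sit), while compound 1 sits at the lower one (the limit of > 1000 nM in this assay, at which 1 of the 3 values shown sits). Nothing among these three marks any compound as more or less toxic than another.

Compound 4 `c1ccc(-c2ccc(Cn3cncc3CNc3ccc(N4CCCCC4)c(-c4ccccc4)c3)cc2)cc1` is the unmeasured analogue of compound 2. The change is piperidin-1-yl in place of phenyl on an aromatic carbon. Among the measured compounds shown here, since every measured compound, including compound 2 with > 10000 nM, stayed at a limit in this assay, there is no step between measured compounds from which the size of this change could be read. The expected step that the limit leaves unreadable from compound 2 to compound 4 is therefore none beyond the scatter, and the most likely outcome is again a limit rather than a number. Compound 4 is expected at 15000 nM, with a range from 5000 nM to 50000 nM.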

Compound 4, half-maximal effective concentration: > 1000 nM
Compound 4: a limit, no number; the forecaster's own chance of this, stated with the estimate: 75%; the middle value lies beyond the limit too.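

In this assay compound 4 gives > 1000 nM, a limit and not a number. Compound 2 gives > 10000 nM, also a limit, so no step can be read between compound 2 and compound 4. The compounds shown leave open what piperidin-1-yl in place of phenyl on an aromatic carbon does to cytotoxicity, and at what concentration any of them reaches a half-maximal effect.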